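Thiophen-2-yl for phenyl in the fluorophenoxy series

A few compounds are considered here, and "the series" means these few. Any claim that something is new, unique, unknown or untested is made for them only; others in the source may bear on it.

compound 1 `Cc1[nH]cnc1/C=c1\[nH]c(=O)/c(=C/c2cccc(Oc3ccc(F)cc3)c2)[nH]c1=O`: 47.6 nM
compound 2 `O=c1[nH]/c(=C\c2cccc(Oc3ccc(F)cc3)c2)c(=O)[nH]/c1=C\c1ccccc1`: 389 nM

Both values come from a functional assay on NCI-H460 cells (Homo sapiens) for cytotoxicity, read by MTT assay, with a stated time of 72 h; on this read-out higher numbers stand for weaker inhibition and lower numbers for stronger inhibition. Compound 2 holds the higher of the two numbers, so it is the weaker inhibitor of this pair. Going by the values given here, the only measured step is an 8.2-fold higher number from compound 1 to compound 2 (0.91 log units; beyond the scatter), and it lies at the same place as the change now in view.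

Compound 3 `O=c1[nH]/c(=C\c2cccs2)c(=O)[nH]/c1=C\c1cccc(Oc2ccc(F)cc2)c1` has thiophen-2-yl in place of phenyl on a double-bonded chain carbon bound to an aromatic carbon.

Among the compounds with values here, no measured compound carries thiophen-2-yl at this place apart from compound 3, so the one step above is the only guide. It shows that the number can move with the group at this place, but it does not predict the outcome for a new group. A smaller shift is therefore expected in this assay, probably slightly downward and perhaps lost in the scatter. The expected step is a 1.6-fold lower number from compound 2 to compound 3 (0.19 log units; within the scatter). For compound 3 the estimated value is 250 nM, with an expected range of 90 nM to 700 nM.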

Compound 3, half-maximal inhibitory concentration: > 1000 nM
Compound 3: no number, only a limit; the forecaster's own chance of this, stated with the estimate: 2%; middle value at least 4.0-fold (0.60 log units) away from the limit.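

In this assay the reading for compound 3 is a limit of the assay and not a number: the limit of > 1000 nM in this assay, at which 1 of the 3 values shown sits.

Replacing phenyl with thiophen-2-yl, one aromatic ring for another, still gives an at least 2.5-fold higher number from compound 2 to compound 3 (0.41 log units; beyond the scatter), so this place on a double-bonded chain carbon bound to an aromatic carbon does not treat these two rings as interchangeable. The gap to the 5-methyl-1H-imidazol-4-yl compound widens to an at least 21-fold higher number from compound 1 to compound 3 (1.32 log units; beyond the scatter), a larger spread than the earlier 8.2-fold higher number from compound 1 to compound 2 (0.91 log units; beyond the scatter), and the three groups fall in a clear order, with 5-methyl-1H-imidazol-4-yl giving the lowest number and thiophen-2-yl the highest.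

Both new steps are lower bounds, so the true size of the loss remains unknown, and the data do not tell what lies behind it. Also open, on these data alone, is whether the advantage of compound 1 depends on the ring nitrogen atoms or on the methyl group, a question that an unsubstituted imidazole, a pyridin-2-yl or a furan-2-yl group at this place could help to separate.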